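This account rests on a few compounds, and the source may have more. Where it says the series, first, only, none or still open, it means among the compounds named here.

In an ADME assay (liver) for metabolic stability, with Liver microsome (Rattus norvegicus) as the target, using microsomes and NADPH, with a stated time of 30 min, tested at 1 uM (on this read-out lower numbers stand for slow clearance and higher numbers for fast clearance), compound 1 (`Nc1ccc(S(=O)(=O)N2CCN(c3ncc(C(O)(C(F)(F)F)C(F)(F)F)cc3C3CC3)CC2)cn1`) reads 27 mL.min-1.g-1 and compound 2 (`Nc1ccc(S(=O)(=O)N2CCN(c3ncc(C(O)(C(F)(F)F)C(F)(F)F)cc3-c3cccnc3)CC2)cn1`) reads 20 mL.min-1.g-1 which lies within the scatter of compound 1. Compound 3 (`COc1ccc(-c2cc(C(O)(C(F)(F)F)C(F)(F)F)cnc2N2CCN(S(=O)(=O)c3ccc(N)nc3)CC2)cn1`) has methoxy in place of hydrogen on an aromatic carbon, turning pyridin-3-yl into 6-methoxypyridin-3-yl. Among the compounds with values here, the only measured step (a 1.4-fold lower number from compound 1 to compound 2 (0.13 log units; within the scatter)) put pyridin-3-yl in place of cyclopropyl and stayed within the scatter, but it is a different change and so only a weak guide. In this assay no step beyond the scatter is expected, and the estimated step is small (a 1.2-fold higher number from compound 2 to compound 3 (0.08 log units; within the scatter)). The estimate for compound 3 is 24 mL.min-1.g-1 with an expected range (12 mL.min-1.g-1 to 48 mL.min-1.g-1).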

Compound 3, intrinsic clearance in microsomes: 265 mL.min-1.g-1
Beside the measured number, compound 3's estimate is 11-fold (1.04 log units) below it, and the stated range ends below it.
By their numbers in this assay, from the lowest: compounds 2 and 1 (each within the scatter of the next); then compound 3.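

In this assay, methoxy in place of hydrogen, on an aromatic carbon next to the ring nitrogen, gives a 13-fold higher number from compound 2 to compound 3 (1.12 log units; beyond the scatter), so this small addition moves the number far more than the swap of cyclopropyl for pyridin-3-yl, which stayed within the scatter. Set against the cyclopropyl compound, 6-methoxypyridin-3-yl gives a 9.8-fold higher number from compound 1 to compound 3 (0.99 log units; beyond the scatter), so compound 3 stands apart from both earlier compounds. No measurement here explains this jump. As far as these compounds go, it remains open whether an amine or a fluorine on that same carbon would raise the number as well, and whether methoxy elsewhere on the ring would do the same.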